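A few compounds are considered here, and "the series" means these few. Any claim that something is new, unique, unknown or untested is made for them only; others in the source may bear on it.

Three compounds share one core and differ only in the group attached to the carbonyl carbon of an amide. Compound 1 `CCC(=O)N(C)c1ccc2[nH]c(-c3n[nH]c4ccccc34)cc2n1` carries an ethyl there, compound 2 `CN(C(=O)C(C)(C)C)c1ccc2[nH]c(-c3n[nH]c4ccccc34)cc2n1` a tert-butyl, and compound 3 `COc1ccc(C(=O)N(C)c2ccc3[nH]c(-c4n[nH]c5ccccc45)cc3n2)cc1` a 4-methoxyphenyl. In a functional assay on KB cells (Homo sapiens) for antiproliferative activity, read by MTT assay, with a stated time of 72 h (a lower number here means a stronger inhibitor, a higher number a weaker inhibitor), compound 1 gives 9300 nM, compound 2 gives 8390 nM and compound 3 gives 12900 nM. Compound 3 thus holds the highest of the three numbers, but the steps are small: a 1.4-fold higher number from compound 1 to compound 3 (0.14 log units; within the scatter) and a 1.5-fold higher number from compound 2 to compound 3 (0.19 log units; within the scatter), while a 1.1-fold lower number from compound 1 to compound 2 (0.04 log units; within the scatter) is equally small. None of these three differences can be told apart from repeat measurement.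

Compound 4 `CN(C(=O)c1ccc([N+](=O)[O-])cc1)c1ccc2[nH]c(-c3n[nH]c4ccccc34)cc2n1` keeps the amide and the phenyl ring of compound 3 and alters one group on that ring: nitro in place of methoxy on an aromatic carbon. For the measured compounds named here, no measured step touches a substituent on this ring; the three steps seen all swap the whole group on the carbonyl carbon, and none of them moved this assay beyond its scatter. Going by the values given here, the only guide is that exchanging an ethyl, a tert-butyl or a 4-methoxyphenyl at that position left the numbers close together. The expected step is therefore a 1.1-fold lower number from compound 3 to compound 4 (0.03 log units; within the scatter), no change beyond the scatter in either direction. Compound 4 is estimated at 12000 nM, with a range from 5000 nM to 30000 nM.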

Compound 4, half-maximal inhibitory concentration: 20200 nM
Compound 4: the middle estimate sits 1.7-fold (0.23 log units) below what was measured; low and high end bracket the measured number.
By their numbers in this assay, from the lowest: compounds 2, 1, 3 and 4 (each within the scatter of the next, the first and the last beyond it).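

Nitro in place of methoxy is the first change seen on the phenyl ring itself, at the carbon para to a large group, and in this assay it gives a 1.6-fold higher number from compound 3 to compound 4 (0.19 log units; within the scatter), so this swap alone cannot be told apart from repeat measurement. For the compounds shown here, the new information comes from setting the 4-nitrophenyl group against the two non-aromatic groups on the carbonyl carbon: tert-butyl to 4-nitrophenyl gives a 2.4-fold higher number from compound 2 to compound 4 (0.38 log units; beyond the scatter), and ethyl to 4-nitrophenyl gives a 2.2-fold higher number from compound 1 to compound 4 (0.34 log units; beyond the scatter), the first steps at this position to pass beyond the scatter, although both are only modest. No measurement of any other property is available to account for these steps.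

Going by these compounds, it remains open how an amine or a carboxylic acid in place of the nitro on the phenyl ring, or a longer chain on the carbonyl carbon, would read in this assay. On these data alone, all four compounds also keep the same methyl on the amide nitrogen, so the effect of a hydrogen or an ethyl there is unknown. As far as these compounds go, compound 2 gives 8390 nM and whether any change could bring the number far lower is unknown as well.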